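The source may hold more compounds than are shown below. What is called first, only, known or untested is meant among the compounds shown, and "the series" means these compounds.

Compound 1 `NS(=O)(=O)c1ccc(N2N=C(c3ccc(Oc4ccccc4)cc3)CC2c2ccccc2)cc1` gives 85000 nM
Compound 2 `Cc1cccc(C2CC(c3ccc(Oc4ccccc4)cc3)=NN2c2ccc(S(N)(=O)=O)cc2)c1` gives 81000 nM
Compound 3 `NS(=O)(=O)c1ccc(N2N=C(c3ccc(Oc4ccccc4)cc3)CC2c2cccc(F)c2)cc1` gives 28000 nM

All three were measured in an ADME assay on Vero 76 cells (Chlorocebus sabaeus) for cytotoxicity, read by MTT assay, with a stated time of 96 h (on this read-out higher numbers stand for lower toxicity in this test and lower numbers for higher toxicity in this test), and compound 3 holds the lowest of the three numbers (28000 nM), with its gaps to both others beyond the scatter. The next compound is compound 4 `Cc1ccc(C2CC(c3ccc(Oc4ccccc4)cc3)=NN2c2ccc(S(N)(=O)=O)cc2)cc1` and it differs from compound 3 on a saturated ring carbon, where 4-methylphenyl comes in place of 3-fluorophenyl (4-methylphenyl in place of 3-fluorophenyl on a saturated ring carbon).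

For the measured compounds named here, three measured steps bear on this change. Methyl in place of hydrogen on an aromatic carbon gave a step within the scatter (a 1.0-fold lower number from compound 1 to compound 2 (0.02 log units; within the scatter)). Fluoro in place of hydrogen gave a modest step (a 3.0-fold lower number from compound 1 to compound 3 (0.48 log units; beyond the scatter)), and fluoro in place of methyl gave one of similar size (a 2.9-fold lower number from compound 2 to compound 3 (0.46 log units; beyond the scatter)). Among these three compounds, then, the fluoro compound stands apart, while the two without fluoro give close numbers. Going by the values given here, no measured compound carries the 4-methylphenyl group itself, so this reading is an extrapolation. Removing the fluoro and adding a methyl is therefore expected to bring the number back up, by a modest amount (a 2.5-fold higher number from compound 3 to compound 4 (0.40 log units; beyond the scatter)). The estimate for compound 4 is 70000 nM with an expected range from 30000 nM to 150000 nM in this test.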

Compound 4, half-maximal cytotoxic concentration: 86000 nM
Compound 4: the middle estimate sits 1.2-fold (0.09 log units) below what was measured; the measured number falls inside the stated range.
By their numbers in this assay, from the lowest: compound 3; then compounds 2, 1 and 4 (each within the scatter of the next).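

In this assay, the exchange of 3-fluorophenyl for 4-methylphenyl on the saturated ring carbon gives a modest step (a 3.1-fold higher number from compound 3 to compound 4 (0.49 log units; beyond the scatter)), so compound 3 now stands apart from a third compound without fluoro, and its steps to all the others lie beyond the scatter. The new compound also shows that moving the methyl makes no measurable difference at this position: the exchange of 3-methylphenyl for 4-methylphenyl stays within the scatter (a 1.1-fold higher number from compound 2 to compound 4 (0.03 log units; within the scatter)), as does the comparison with the unsubstituted phenyl of compound 1 (a 1.0-fold higher number from compound 1 to compound 4 (0.01 log units; within the scatter)), which leaves compounds 1, 2 and 4 indistinguishable in this test. Nothing shown here explains why compound 3 alone departs from the others.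

The compounds shown leave open whether the lower number follows the fluoro group wherever it sits on this ring, since a 4-fluorophenyl group does not appear among them, and whether a 3-chlorophenyl group would behave like 3-fluorophenyl. They also leave open how groups of another kind, such as a methoxy group, an amine or a carboxylic acid, would read on this phenyl ring.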